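This account rests on a few compounds, and the source may have more. Where it says the series, first, only, none or still open, it means among the compounds named here.

Compound 1 `Cc1ncc([N+](=O)[O-])n1CC(O)CSC(=S)N1CCCC(C)C1` gives 609000 nM in a toxicity assay on HeLa cells (Homo sapiens) for cytotoxicity, read by MTT assay, with a stated time of 24 h; on this read-out lower numbers stand for stronger inhibition and higher numbers for weaker inhibition.
Compound 2 `Cc1ncc([N+](=O)[O-])n1CC(O)CSC(=S)N(C)C` gives > 5000000 nM in this assay.

Compound 2 stands at a limit of the assay, not at a measured number (the limit of > 5000000 nM in this assay, at which 1 of the 2 values shown sits). Compound 3 `CCN(CC)C(=S)SCC(O)Cn1c([N+](=O)[O-])cnc1C` differs from compound 2 by diethylamino in place of dimethylamino on a thiocarbonyl carbon. Within the data shown here, the one measured step that bears on this change is an at least 8.2-fold higher number from compound 1 to compound 2 (0.91 log units; beyond the scatter), where a smaller amine on the thiocarbonyl carbon went with a higher number. A diethylamino is larger than a dimethylamino, so a drop to a lower number is expected in this assay, though the change is not the same as the measured one, so only a modest drop is expected, an at least 2.0-fold lower number from compound 2 to compound 3 (0.30 log units; that floor lies within the scatter). For compound 3 the estimate is 2500000 nM, between 600000 nM and 8000000 nM.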

Compound 3, half-maximal inhibitory concentration: 2460000 nM
For compound 3 the middle estimate is 1.0-fold (0.01 log units) above the measured one; the measured number falls inside the stated range.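

In this assay the amine on the thiocarbonyl carbon now has a second measured point, and a 4.0-fold higher number from compound 1 to compound 3 (0.61 log units; beyond the scatter) shows that diethylamino does not match 3-methylpiperidin-1-yl. The other comparison, an at least 2.0-fold lower number from compound 2 to compound 3 (0.30 log units; that floor lies within the scatter), is only a floor, so the gain over dimethylamino may be small or larger. Compound 2 stands at a limit, not a number: the limit of > 5000000 nM in this assay, at which 1 of the 3 values shown sits.

On these data alone, whether the ring or simply the size of the amine sets the number remains open. Piperidin-1-yl without the methyl, morpholin-4-yl or dipropylamino could help separate the two.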